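Swapping the Aryl Group on a Sulfonamide Nitrogen

This account rests on a few compounds, and the source may have more. Where it says the series, first, only, none or still open, it means among the compounds named here.

In a functional assay on MCF7 cells (Homo sapiens) for antiproliferative activity, read by MTT assay, with a stated time of 72 h (a higher number here means a weaker inhibitor, a lower number a stronger inhibitor), compound 1 (`CN(c1ccc(Cl)cc1)S(=O)(=O)C1CC2OC1C(c1ccc(NC(=O)CCCCCCC(=O)O)cc1)=C2c1ccc(O)cc1`) gives 13700 nM and compound 2 (`CCN(c1cccc(OC)c1)S(=O)(=O)C1CC2OC1C(c1ccc(NC(=O)CCCCCCC(=O)O)cc1)=C2c1ccc(O)cc1`) stands higher with 37400 nM as the weaker of the pair. Compound 3 (`CCN(c1ccccc1Cl)S(=O)(=O)C1CC2OC1C(c1ccc(NC(=O)CCCCCCC(=O)O)cc1)=C2c1ccc(O)cc1`) takes 2-chlorophenyl in place of 3-methoxyphenyl on a sulfonamide nitrogen. Among the measured compounds shown here, the only measured step bearing on this is modest (a 2.7-fold higher number from compound 1 to compound 2 (0.44 log units; beyond the scatter)) and also changed the groups on that nitrogen. Compound 3 keeps the ethyl of compound 2 but carries a chlorophenyl like compound 1 (13700 nM) so a small move toward a lower number is expected. The estimated change in this assay is small (a 1.7-fold lower number from compound 2 to compound 3 (0.23 log units; within the scatter)). Compound 3 is expected at 22000 nM with an estimated range (9000 nM to 50000 nM).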

Compound 3, half-maximal inhibitory concentration: 33300 nM
Estimate against measurement, compound 3: 1.5-fold (0.18 log units) below; measured number inside the range.
By their numbers in this assay, from the lowest: compound 1; then compounds 3 and 2 (each within the scatter of the next).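

In this assay the step from 3-methoxyphenyl to 2-chlorophenyl gives a 1.1-fold lower number from compound 2 to compound 3 (0.05 log units; within the scatter) and does not separate the two compounds while the ethyl stays. The other comparison gives a 2.4-fold higher number from compound 1 to compound 3 (0.39 log units; beyond the scatter) even though both compounds carry a chlorophenyl, so having a chlorophenyl on this nitrogen is not enough to match compound 1. Nothing available explains these numbers. Methyl and ethyl changed together with the chlorine's place on the ring, and which change matters stays open. A (4-chlorophenyl)(ethyl)amino group would separate the two.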